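The source may hold more compounds than are shown below. What is called first, only, known or untested is meant among the compounds shown, and "the series" means these compounds.

Measured so far in an assay on CHO cells for displacement of a labelled ligand from prostaglandin E2 receptor EP3 subtype (Homo sapiens), read by radioligand binding; on this read-out higher numbers stand for weaker inhibition and lower numbers for stronger inhibition:
- compound 1 `CC(C)NC(=O)CC(c1ccc(-c2ccc3cccc(F)c3c2)[nH]c1=O)C(C)C`: 5.8 nM
- compound 2 `CC(C)C(c1ccc(-c2ccc3cccc(F)c3c2)[nH]c1=O)N1CCCCC1=O`: 6.4 nM

Among the measured compounds shown here, the two numbers sit within the scatter of each other: the only measured step is a 1.1-fold higher number from compound 1 to compound 2 (0.04 log units; within the scatter), so the two stand level. For the measured compounds named here, the single measured step therefore shows that exchanging (isopropylcarbamoyl)methyl for 2-oxopiperidin-1-yl on the saturated chain carbon bound to an aromatic carbon and a saturated chain carbon left the read-out unchanged.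

Compound 3 `CC(C)C(Cc1ncc[nH]1)c1ccc(-c2ccc3cccc(F)c3c2)[nH]c1=O` is not yet measured. It differs from compound 2 as follows: (1H-imidazol-2-yl)methyl in place of 2-oxopiperidin-1-yl on a saturated chain carbon bound to an aromatic carbon and a saturated chain carbon. Going by the values given here, the only step that bears on it is the one from compound 1 to compound 2, which was within the scatter; it speaks for tolerance at this position, but both groups compared there carry a carbonyl, whereas the entering group is an aromatic ring with a hydrogen-bond donor, for which no measured pair exists. For compound 3 the expected step is a 2.3-fold higher number from compound 2 to compound 3 (0.37 log units; beyond the scatter), a modest lean toward a higher number with a wide range. In this assay compound 3 is estimated at 15 nM, range 4 nM to 60 nM.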

Compound 3, inhibition constant: 11 nM
For compound 3 the middle estimate is 1.4-fold (0.13 log units) above the measured one, within the range that was stated.
By their numbers in this assay, from the lowest: compounds 1, 2 and 3 (each within the scatter of the next).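

Across these three compounds, the group on the saturated chain carbon bound to an aromatic carbon and a saturated chain carbon need not contain a carbonyl: in this assay, (1H-imidazol-2-yl)methyl in place of 2-oxopiperidin-1-yl gives (a 1.7-fold higher number from compound 2 to compound 3 (0.24 log units; within the scatter)), and 1H-imidazol-2-yl in place of isopropylcarbamoyl on the saturated chain carbon, two bonds along the chain from an aromatic carbon, gives (a 1.9-fold higher number from compound 1 to compound 3 (0.28 log units; within the scatter)). The tolerated range at this place therefore extends beyond the two carbonyl-bearing groups to a five-membered aromatic ring with a hydrogen-bond donor, and the three compounds stand level. No measurement available here explains this levelness.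

Still open, going by these compounds, is whether a benzyl group, without ring nitrogens, or (1-methyl-1H-imidazol-2-yl)methyl, without the ring's hydrogen-bond donor, would stay level with (1H-imidazol-2-yl)methyl in this assay. Also open is whether a primary amine, a carboxylic acid or a longer chain ending in the same imidazole ring would be tolerated at this place, since the compounds shown do not define where the tolerance ends.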